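The source may report more compounds than this note shows. Statements on the series, on what has been measured and on what is new or still open speak of the compounds shown alone.

In a functional assay on MIA PaCa-2 cells (Homo sapiens) for antiproliferative activity, read by sulforhodamine B assay, with a stated time of 48 h (a higher number here means a weaker inhibitor of growth, a lower number a stronger inhibitor of growth), the three measured compounds stand as follows:

Compound 1 `O=C(NCc1cn(Cc2ccc(Cl)cc2)nn1)c1cn(-c2ccccc2)nc1-c1ccccc1` gives 8700 nM.
Compound 2 `O=C(NCc1cn(Cc2ccc(C(F)(F)F)cc2)nn1)c1cn(-c2ccccc2)nc1-c1ccccc1` gives 17700 nM.
Compound 3 `COc1ccc(Cn2cc(CNC(=O)c3cn(-c4ccccc4)nc3-c3ccccc3)nn2)cc1` gives 10200 nM.

Compound 2 has the highest of the three numbers, so it is the weakest grower-inhibitor of the set. The step of a 2.0-fold higher number from compound 1 to compound 2 (0.31 log units; beyond the scatter) is the only one that goes beyond the usual scatter of repeats. The step of a 1.7-fold lower number from compound 2 to compound 3 (0.24 log units; within the scatter) stays within that scatter, so compound 2 and compound 3 cannot be told apart on these numbers.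

Compound 4 `O=C(NCc1cn(Cc2ccc(C(F)(F)F)cc2)nn1)c1cn(-c2ccccc2)nc1-c1ccc(Cl)cc1` is the next compound. Compared with compound 2 the change is chloro in place of hydrogen on an aromatic carbon. All three measured steps concern a different place in the molecule: the group on the benzyl ring attached to the triazole, where chloro, trifluoromethyl and methoxy were exchanged. None of them touches the phenyl ring on the shared core where compound 4 carries its new chloro. Going by the values given here, there is therefore no measured step that bears directly on this change, and the only reasonable expectation is a step in this assay that does not go beyond the scatter, in either direction.

Compound 4 is accordingly expected to give about 15000 nM, within a range from 5000 nM to 45000 nM. For compound 4 the expected change is a 1.2-fold lower number from compound 2 to compound 4 (0.07 log units; within the scatter).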

Compound 4, concentration for 50% growth inhibition: 1100 nM
Beside the measured number, compound 4's estimate is 14-fold (1.13 log units) above it, outside the stated range (below it).
By their numbers in this assay, from the lowest: compound 4; then compounds 1, 3 and 2 (each within the scatter of the next, the first and the last beyond it).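

In this assay, the single chloro that turns phenyl into 4-chlorophenyl on the shared core gives a 16-fold lower number from compound 2 to compound 4 (1.21 log units; beyond the scatter), so this ring is a place where adding one heavy atom moves the number much further than any earlier exchange did. The earlier steps shown here all lay on the benzyl ring attached to the triazole, and only one of them went beyond the scatter, so they gave no sign that growth inhibition could respond this strongly to a change elsewhere in the molecule. Nothing available here explains how the chloro produces this difference.

From the compounds shown here alone, it remains open whether this gain belongs to chloro itself or would also come with another group in the same place, such as fluoro, an amine or a carboxylic acid. Going by these compounds, it is also open whether the new chloro would lower the number to a similar degree with the chloro of compound 1 or the methoxy of compound 3 on the benzyl ring, as it is seen here only with trifluoromethyl there.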